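Adding a (4-chlorophenyl)carbamoyl Arm to Compound 1

The source may hold more compounds than are shown below. What is called first, only, known or untested is meant among the compounds shown, and "the series" means these compounds.

Compound 1 `COc1ccc(-n2c(SC)nnc2-c2cc(OC)c(OC)c(OC)c2)cc1`: > 60000 nM
Compound 2 `COc1ccc(NC(=O)CSc2nnc(-c3cc(OC)c(OC)c(OC)c3)n2-c2ccc(OC)cc2)cc1`: 25800 nM

In a functional assay on PC-3 cells (Homo sapiens) for inhibition, read by MTT assay, with a stated time of 48 h (on this read-out higher numbers stand for weaker inhibition and lower numbers for stronger inhibition), compound 1 reaches only a limit of the assay, > 60000 nM, and no number. In this assay compound 2 gives 25800 nM. Among the measured compounds shown here, the one measured step, an at least 2.3-fold lower number from compound 1 to compound 2 (0.36 log units; beyond the scatter), shows that growing a carbamoyl arm from the methylsulfanyl carbon brought the number down. Compound 3 `COc1ccc(-n2c(SCC(=O)Nc3ccc(Cl)cc3)nnc2-c2cc(OC)c(OC)c(OC)c2)cc1` differs from compound 1 in the same place: (4-chlorophenyl)carbamoyl in place of hydrogen on a saturated chain carbon bound to a sulfur. Because that parallel step an at least 2.3-fold lower number from compound 1 to compound 2 (0.36 log units; beyond the scatter) was at least modest, a similar drop is expected here, an at least 3.0-fold lower number from compound 1 to compound 3 (0.47 log units; beyond the scatter). Compound 3 is therefore estimated at 20000 nM, within 6000 nM to 60000 nM.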

Compound 3, half-maximal inhibitory concentration: 6290 nM
The estimate for compound 3 lay 3.2-fold (0.50 log units) above the measured number; low and high end bracket the measured number.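

The (4-chlorophenyl)carbamoyl arm also lowers the number, so the effect is not confined to the arm of compound 2: an at least 9.5-fold lower number from compound 1 to compound 3 (0.97 log units; beyond the scatter). The end of the arm matters too, since chloro in place of methoxy on an aromatic carbon gives a 4.1-fold lower number from compound 2 to compound 3 (0.61 log units; beyond the scatter). Compound 1 gives only a limit, so the first of these steps is a bound rather than a size: the limit of > 60000 nM in this assay, at which 1 of the 3 values shown sits.

Still open, as far as these compounds go, is how fluoro, bromo or an unsubstituted phenyl would compare with the 4-chlorophenyl group. A longer chain carrying the same amide is also untested among these compounds.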